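Trading methoxycarbonyl for hydroxy on a shared core

The source may report more compounds than this note shows. Statements on the series, on what has been measured and on what is new or still open speak of the compounds shown alone.

Three relatives sharing one core have been measured in a toxicity assay on CCRF-CEM cells (Homo sapiens) for cytotoxicity; on this read-out lower numbers stand for higher toxicity in this test and higher numbers for lower toxicity in this test. Compound 1 `Cc1cccc2c1nc(-c1c(F)cccc1F)n2Cc1c(F)cccc1F` reports > 100 uM, which is a limit of the assay and not a number. Compound 2 `CCc1cccc2c1nc(-c1c(F)cccc1F)n2Cc1c(F)cccc1F` gives 26.1 uM, and compound 3 `COC(=O)c1cccc2c1nc(-c1c(F)cccc1F)n2Cc1c(F)cccc1F` gives 57.7 uM, the higher of the two actual numbers.

The next relative is compound 4 `Oc1cccc2c1nc(-c1c(F)cccc1F)n2Cc1c(F)cccc1F`, with hydroxy in place of methoxycarbonyl on an aromatic carbon. Among the measured compounds shown here, no measured step makes this exact swap, but three steps change a group on the same carbon. These are an at least 3.8-fold lower number from compound 1 to compound 2 (0.58 log units; beyond the scatter), a 2.2-fold higher number from compound 2 to compound 3 (0.34 log units; beyond the scatter) and an at least 1.7-fold lower number from compound 1 to compound 3 (0.23 log units; that floor lies within the scatter). The first two run in opposite directions, and the clearly measured one, a 2.2-fold higher number from compound 2 to compound 3 (0.34 log units; beyond the scatter), is only modest. They give no basis for choosing a direction, so no step beyond the scatter is expected in this assay. The expected change is a 1.0-fold lower number from compound 3 to compound 4 (0.02 log units; within the scatter). For compound 4 the estimate is 55 uM, with an expected range from 18 uM to 100 uM.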

Compound 4, half-maximal toxic concentration: > 100 uM
Compound 4 was reported as a limit; the forecaster's own chance of this, stated with the estimate: 25%; middle value at least 1.8-fold (0.25 log units) from the limit.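

Compound 4 gives > 100 uM in this assay, which is a limit of the assay and not a number. Hydroxy in place of ethyl gives an at least 3.8-fold higher number from compound 2 to compound 4 (0.58 log units; beyond the scatter), so compound 2, with ethyl on this aromatic carbon, now has the lowest number, with a step beyond the scatter to each of the other three compounds. Hydroxy in place of methoxycarbonyl gives an at least 1.7-fold higher number from compound 3 to compound 4 (0.23 log units; that floor lies within the scatter), which does not establish a real change, and the step between compound 1 and compound 4 cannot be read because both are limits: the limit of > 100 uM in this assay, at which 2 of the 4 values shown sit.

The compounds shown do not tell what an amine, a carboxylic acid or a longer chain would give on this carbon. As far as these compounds go, whether hydroxy and methyl differ at all in this assay also stays open.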